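The compounds below may be only part of what the source reports. "The series", "measured", "known", "first", "only" and "open" are said of these compounds alone.

Readings in an ADME assay on microsomes from liver (Homo sapiens) for metabolic stability, read by LC-MS, using NADPH, with a stated time of 10 min, tested at 10 uM (on this read-out higher numbers stand for a longer-lived compound and lower numbers for a shorter-lived compound), for the series so far
compound 1 `N#Cc1ccnc(Oc2nn([C@H]3C[C@H](O)C3)c3ncnc(N)c23)c1` gives > 2.41 h as a limit of the assay and not a number
compound 2 `CC(C)(C)n1nc(Oc2cc(O)ccn2)c2c(N)ncnc21` gives 1.4 h
compound 3 `Nc1ncnc2c1c(Oc1cc(O)ccn1)nn2[C@H]1C[C@H](F)C1` gives 1.03 h

Among the compounds with values here, compound 2 and compound 3 hold the only two true numbers (a 1.4-fold lower number from compound 2 to compound 3 (0.13 log units; within the scatter)). That step, 3-fluorocyclobutyl in place of tert-butyl on an aromatic nitrogen, lies at a different place from the change considered here. Compound 4 `CC(C)(C)n1nc(Oc2cc(C#N)ccn2)c2c(N)ncnc21` keeps the tert-butyl of compound 2 and takes cyano in place of hydroxy on an aromatic carbon, opposite the ring nitrogen (cyano in place of hydroxy on an aromatic carbon). Within the data shown here, no measured step makes this change. Compound 1 also carries cyano, and its reading is a limit (the limit of > 2.41 h in this assay, at which 1 of the 3 values shown sits). On that limit alone, only a small rise is expected in this assay for compound 4. The estimated step (a 1.3-fold higher number from compound 2 to compound 4 (0.11 log units; within the scatter)) is expected to stay modest. Compound 4 is estimated at 1.8 h (range 0.8 h to 4 h).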

Compound 4, half-life: > 2.41 h
Compound 4 ended at the assay's limit; the forecaster's own chance of this, stated with the estimate: 30%; middle value at least 1.3-fold (0.12 log units) away from the limit.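

This position, opposite the ring nitrogen, now has its first pair differing in this one place: in this assay, cyano in place of hydroxy gives an at least 1.7-fold higher number from compound 2 to compound 4 (0.23 log units; that floor lies within the scatter). Compound 4 gives > 2.41 h, which is a limit and not a number, so this step is only a floor on the size of the change. The step between compound 1 and compound 4, which changes the group on the aromatic nitrogen, cannot be read, and neither compound holds a true number: the limit of > 2.41 h in this assay, at which 2 of the 4 values shown sit.

Going by these compounds, the true size of the cyano step remains open, and a reading for compound 4 within the range of the assay would be needed to settle it. Also open, on these data alone, is what a methoxy group or an amine would give at this position on the same core.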